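Adding a Second Fluoro Group: What to Expect

The source may report more compounds than this note shows. Statements on the series, on what has been measured and on what is new or still open speak of the compounds shown alone.

Compound 1 `O=C1C=C(Nc2ccccc2)C(=O)c2cnccc21` gives 439 nM in a functional assay (aorta) for inhibition, with Rattus norvegicus as the target; on this read-out lower numbers stand for an effect already at smaller amounts and higher numbers for an effect only at larger amounts of compound.
Compound 2 `O=C1C=C(Nc2cccc(F)c2)C(=O)c2cnccc21` gives 562 nM in this assay.

Compound 2 has the highest of the two numbers, yet the step of a 1.3-fold higher number from compound 1 to compound 2 (0.11 log units; within the scatter) lies within the scatter, so the two compounds cannot be told apart on this read-out. Compound 3 `O=C1C=C(Nc2cc(F)cc(F)c2)C(=O)c2cnccc21` has not been measured. It differs from compound 2 by fluoro in place of hydrogen on an aromatic carbon, the new group sitting on an aromatic carbon of a six-membered aromatic ring of carbon only, meta to a fluoro group. Among the compounds with values here, only one measured step bears on this change, the first fluoro going from compound 1 to compound 2, and it stayed within the scatter. A second fluoro of the same kind is therefore expected to move this assay little, if at all, with the expected step being a 1.2-fold higher number from compound 2 to compound 3 (0.06 log units; within the scatter). For compound 3 the estimate is 650 nM, with a range from 300 nM to 1400 nM.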

Compound 3, half-maximal effective concentration: 290 nM
Estimate against measurement, compound 3: 2.2-fold (0.35 log units) above, and the stated range ends above it.
By their numbers in this assay, from the lowest: compounds 3, 1 and 2 (each within the scatter of the next).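

Adding a fluoro group meta to the first one gives a 1.9-fold lower number from compound 2 to compound 3 (0.29 log units; within the scatter) in this assay and so stays inside the usual scatter, just as the first fluoro step did. Neither step stands clear of that scatter, so this read-out shows no trend with the number of fluoro groups across compound 1, compound 2 and compound 3: at this position, one more fluoro group in place of hydrogen makes no change that can be told apart. Nothing available here explains why the number of compound 3 came out where it did.

All the substituents shown on this ring are fluoro groups, so it stays open whether methoxy, an amine or a carboxylic acid at this position would also leave the read-out in place. Also open, from the compounds shown here alone, is how a fluoro group on any other ring carbon would behave.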